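Removing a Trifluoromethyl from an Amide-Bearing Pyrazole Series

The source may report more compounds than this note shows. Statements on the series, on what has been measured and on what is new or still open speak of the compounds shown alone.

Compound 1 `O=C(Nc1cccc(-n2cc(-c3ccncc3)c(-c3ccc(Cl)c(O)c3)n2)c1)Nc1cccc(C(F)(F)F)c1` — a functional assay on T47D cells (Homo sapiens) for inhibition, read by sulforhodamine B assay, with a stated time of 48 h; a higher number here means that more compound is tolerated, a lower number that less compound is tolerated: > 32500 nM
Compound 2 `COc1cc(-c2nn(-c3cccc(NC(=O)c4cccc(C(F)(F)F)c4)c3)cc2-c2ccncc2)ccc1Cl` — this assay: > 50000 nM
Compound 3 `O=C(Nc1cccc(-n2cc(-c3ccncc3)c(-c3ccc(Cl)c(O)c3)n2)c1)Nc1cc(C(F)(F)F)cc(C(F)(F)F)c1` — this assay: > 50000 nM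

In this assay compound 2 reaches only a limit of the assay, > 50000 nM, not a number. The same holds for the other two compounds shown: compound 1 sits at the limit of > 32500 nM in this assay, at which 1 of the 3 values shown sits, and compound 3, like compound 2, sits at the limit of > 50000 nM in this assay, at which 2 of the 3 values shown sit. Going by the values given here, the one comparison that can be drawn among them, a step that the two limits leave unreadable from compound 1 to compound 3, therefore gives no readable size.

Compound 4 `COc1cc(-c2nn(-c3cccc(NC(=O)c4ccccc4)c3)cc2-c2ccncc2)ccc1Cl` differs from compound 2 by hydrogen in place of trifluoromethyl on an aromatic carbon. Among the compounds with values here, no measured step in this set involves the same change, and the only step available is unreadable, so no direction or size beyond the scatter can be expected for this assay. Compound 4 is therefore estimated to sit at the same limit as compound 2, with a step of a number no higher from compound 2 to compound 4 (the limit leaves the size open) expected, that is, none that can be read. The expected value for compound 4 is 50000 nM, within 20000 nM to 100000 nM.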

Compound 4, concentration lethal to 50% of the cells: > 100000 nM
Compound 4 ended at the assay's limit; the forecaster's own chance of this, stated with the estimate: 80%; middle value at least 2.0-fold (0.30 log units) from the limit.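

Compound 2 and compound 4 both end at limits of this assay rather than at numbers, and the step between them cannot be read. The compounds shown leave open whether hydrogen in place of trifluoromethyl changes the result in this assay at all, and what actual number any compound here would reach.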